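A few compounds are considered here, and "the series" means these few. Any claim that something is new, unique, unknown or untested is made for them only; others in the source may bear on it.

Of the compounds shown here, three have so far been measured in an assay on HEK293 cells for positive allosteric modulation of metabotropic glutamate receptor 5 (Homo sapiens), read by FLIPR; on this read-out lower numbers stand for an effect already at smaller amounts and higher numbers for an effect only at larger amounts of compound. Compound 1 `O=C(c1ccc(Cl)cc1)N1CC(c2nc(-c3cccc(F)c3)no2)C1` gives 2500 nM and is the only one of the three to yield a number. Compound 2 `Cc1cccc(-c2noc(C3CN(S(=O)(=O)c4cccc(C)c4)C3)n2)c1` reaches only the limit of > 10000 nM in this assay. Compound 3 `O=C(C1CCCO1)N1CC(c2nc(-c3cccc(Cl)c3)no2)C1` likewise gives only the limit of > 10000 nM in this assay. Among the compounds with values here, compound 1 therefore stands alone as the one value that can be read as a number, while the other two sit at the limit of > 10000 nM in this assay, at which 2 of the 3 values shown sit.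

Compound 4 `Cc1ccc(C(=O)N2CC(c3nc(-c4cccc(F)c4)no3)C2)cc1` differs from compound 1 in a single place: methyl in place of chloro on an aromatic carbon. Within the data shown here, no pair of measured compounds shows what this exchange does, so any expectation rests on the value of compound 1 alone. The step of a 1.2-fold higher number from compound 1 to compound 4 (0.08 log units; within the scatter) in this assay is expected to stay within the usual scatter, in neither direction beyond it. Compound 4 is accordingly estimated at 3000 nM in this assay, with a range from 1000 nM to 10000 nM.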

Compound 4, half-maximal effective concentration: 6800 nM
For compound 4 the middle estimate is 2.3-fold (0.36 log units) below the measured one, and the stated range covers the measured number.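

Within the data shown here, the exchange of 4-chlorophenyl for 4-methylphenyl gives the first step in this assay that can be read between compounds differing in one place: a 2.7-fold higher number from compound 1 to compound 4 (0.43 log units; beyond the scatter). At this position on the aromatic ring, para to a large group, chloro therefore gives the lower number, although the step is modest and the two groups count the same single heavy atom and no hydrogen-bond donors or acceptors. Compound 4 still gives a number, and the only limits among the values shown remain those of compounds 2 and 3: the limit of > 10000 nM in this assay, at which 2 of the 4 values shown sit.

From the compounds shown here alone, whether a methoxy group, an amine or a carboxylic acid at this position would lower or raise the number remains open. A single step also cannot tell why chloro and methyl differ here, or whether the same exchange would have a similar effect on another compound.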